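Chain length and whole-organism inhibition in the shared-core series

A few compounds are considered here, and "the series" means these few. Any claim that something is new, unique, unknown or untested is made for them only; others in the source may bear on it.

Measured so far:
Compound 1 `CCCCCCCCCCCCCCC1(C(=O)OCC(O)CO)CO1` gives 10 uM in a functional assay for inhibition, with Rattus norvegicus as the target; a higher number here means that more compound is needed for the effect, a lower number that less compound is needed.
Compound 2 `CCCCCCC1(C(=O)OC)CO1` gives 20 uM in this assay.
Compound 3 `CCCCCCCCCCCC1(C(=O)OC)CO1` gives 2.5 uM in this assay.

Compound 3 stands at the lowest number of the three in this assay: compound 1 sits at a higher number, and compound 2 higher still. Among the compounds with values here, the only measured step between neighbours is an 8.0-fold lower number from compound 2 to compound 3 (0.90 log units; beyond the scatter), a chain extension that brought the number down.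

Compound 4 `CCCCCCCCCCC1(C(=O)OC)CO1` differs from compound 3 by hydrogen in place of methyl on a saturated chain carbon, ten or more bonds along the chain from a saturated ring carbon. This is a chain shortening by a single carbon at the far end, the reverse direction of the step from compound 2 to compound 3 but far smaller in extent. Within the data shown here, the one bearing step, an 8.0-fold lower number from compound 2 to compound 3 (0.90 log units; beyond the scatter), covered five carbons; one carbon should move the number only a little upward, probably near the edge of the scatter.

For compound 4 the expected value in this assay is 3.5 uM, with a range of 1.8 uM to 7 uM. The expected step is therefore a 1.4-fold higher number from compound 3 to compound 4 (0.15 log units; within the scatter).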

Compound 4, minimum effective concentration: 0.5 uM
The estimate for compound 4 lay 7.0-fold (0.85 log units) above the measured number; measured number below the stated range.
By their numbers in this assay, from the lowest: compound 4; then compound 3; then compounds 1 and 2 (each within the scatter of the next).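

In this assay, hydrogen in place of methyl on a saturated chain carbon, ten or more bonds along the chain from a saturated ring carbon, gives a 5.0-fold lower number from compound 3 to compound 4 (0.70 log units; beyond the scatter), so a single carbon at this far end of the chain carries a step beyond the scatter. Among compounds 2, 3 and 4, number does not follow chain length in one direction: a 40-fold lower number from compound 2 to compound 4 (1.60 log units; beyond the scatter) is larger than the step to the longer chain of compound 3, which places the lowest number at the intermediate chain of compound 4. Nothing available bears on why removing this one carbon lowers the number.

As far as these compounds go, whether chains just shorter than that of compound 4 give a still lower number remains open. Also open, from the compounds shown here alone, is whether a carboxylic acid or an amide in place of the ester of compound 4 keeps the number this low.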